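This account rests on a few compounds, and the source may have more. Where it says the series, first, only, none or still open, it means among the compounds named here.

Working notes on the series. Compound 1 `COc1cc2nccc(Oc3ccc(Nc4nn(C)cc4C(=O)Nc4ccccc4)cc3)c2cc1C(N)=O` stands at the edge of the measured scale in a functional assay on BaF3 cells (Mus musculus) for antiproliferative activity, read by CCK-8 assay and cell counting, with a stated time of 76 h; a lower number here means a stronger inhibitor, a higher number a weaker inhibitor: compound 1 gives > 10000 nM, which is a limit of the assay and not a number. Compound 2 `COc1cc2nccc(Oc3ccc(Nc4nn(C)cc4C(=O)NC45CCC(CC4)CC5)cc3)c2cc1C(N)=O` gives > 10000 nM, likewise a limit. Compound 3 `COc1cc2nccc(Oc3ccc(Nc4nn(C)cc4C(=O)NCC4CCCCC4)cc3)c2cc1C(N)=O` gives > 10000 nM, again a limit. The measured steps a step that the two limits leave unreadable from compound 1 to compound 2, a step that the two limits leave unreadable from compound 1 to compound 3 and a step that the two limits leave unreadable from compound 2 to compound 3 therefore carry no readable size, because of the limit of > 10000 nM in this assay, at which 3 of the 3 values shown sit. Compound 4 `COc1cc2nccc(Oc3ccc(Nc4nn(C)cc4C(=O)NC4CCCC4)cc3)c2cc1C(N)=O` differs from compound 1 by cyclopentyl in place of phenyl on an amide-type nitrogen. The measured steps bear on it only as further replacements on the same amide-type nitrogen, none of which moved off the limit. The step from compound 1 to compound 4 is expected to be a step that the limit leaves unreadable from compound 1 to compound 4, with no readable direction. Compound 4 is estimated at 20000 nM, between 7000 nM and 60000 nM, most likely reported again as a limit.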

Compound 4, half-maximal inhibitory concentration: > 10000 nM
Compound 4: only a limit was reported; the forecaster's own chance of this, stated with the estimate: 85%; the middle value lies beyond the limit too.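

No step can be read for compound 4 against compound 1, compound 2 or compound 3, since all four sit at one limit: the limit of > 10000 nM in this assay, at which 4 of the 4 values shown sit.

The compounds shown leave open which amide-nitrogen group, if any, would bring a measurable value in this assay.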